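The compounds below may be only part of what the source reports. "The series", "measured", "known", "first", "only" and "open" are said of these compounds alone.

Compound 2 `CCN(CC)CCn1cnnc1-c1cc(Oc2ccc(NC(=O)Nc3ccc(F)c(F)c3)cc2F)ccn1` stands at the bottom of the two numbers at hand: in an assay on isolated protein for inhibition of proto-oncogene tyrosine-protein kinase receptor Ret (Homo sapiens), read by mobility shift assay, with a stated time of 1 h, tested at 10 uM (on this read-out lower numbers stand for less inhibition and higher numbers for more inhibition at the one concentration tested (going by the name of the read-out)), compound 2 gives 7.1%. Among the measured compounds shown here, its only measured neighbour is compound 1 `CCN(CC)CCn1cnnc1-c1cc(Oc2ccc(NC(=O)Nc3ccc(Cl)c(C(F)(F)F)c3)cc2F)ccn1`, which in this assay gives 84.4%; the one measured step, a number 77.3 percentage points lower from compound 1 to compound 2 (beyond the scatter), is the sole guide here. The unmeasured compound 3 `CCN(CC)CCn1cnnc1-c1cc(Oc2ccc(NC(=O)Nc3ccc(F)c(Cl)c3)cc2F)ccn1` differs from compound 2 by chloro in place of fluoro on an aromatic carbon. For the measured compounds named here, that is the same aryl ring on the urea nitrogen that the single measured step changed, and because a number 77.3 percentage points lower from compound 1 to compound 2 (beyond the scatter) was large when the heavier halogenated aryl was swapped out, bringing a chloro back onto that ring is expected to move this assay upward, though not to the height of compound 1. The expected change is a number 32.9 percentage points higher from compound 2 to compound 3 (beyond the scatter). For compound 3 the estimate in this assay is 40%, with a plausible range from 10% to 75%.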

Compound 3, a percentage reported as inhibition, at one concentration (the size of the read-out at that concentration, not a potency): 1.9%
Compound 3: middle estimate off by 38.1 percentage points, on the high side, and the stated range ends above it.
By their numbers in this assay, from the lowest: compounds 3 and 2 (each within the scatter of the next); then compound 1.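

In this assay, chloro in place of fluoro on this aromatic carbon, ortho to a fluoro group, gives a number 5.2 percentage points lower from compound 2 to compound 3 (within the scatter), so this halogen exchange does not separate the two compounds. Having a chloro on the ring is also not enough to approach compound 1: 3-chloro-4-fluorophenyl in place of 4-chloro-3-(trifluoromethyl)phenyl corresponds to a number 82.5 percentage points lower from compound 1 to compound 3 (beyond the scatter). No available evidence bears on the reason for this result.

The compounds leave open whether the trifluoromethyl, the chloro or the two together within 4-chloro-3-(trifluoromethyl)phenyl account for the reading of compound 1. They also leave open how a methyl, a methoxy or a nitrile on this same aromatic carbon would read in this assay.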